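Swapping the amine substituent in a ghrelin receptor series

The source may hold more compounds than are shown below. What is called first, only, known or untested is meant among the compounds shown, and "the series" means these compounds.

Compound 1 `COc1cccc(-n2cc3nc(-c4cccnc4C)n(C[C@H]4CCCN(CC5CCCC5)C4)c(=O)c3n2)c1`: 12 nM
Compound 2 `COc1cccc(-n2cc3nc(-c4cccnc4C)n(C[C@H]4CCCN(CC5CCCCO5)C4)c(=O)c3n2)c1`: 120 nM

The two measured compounds share one core and differ only in the group on a saturated chain carbon bound to an amine nitrogen in a ring. In an assay on HEK293 cells for displacement of a labelled ligand from growth hormone secretagogue receptor type 1 (Homo sapiens), with a stated time of 60 min (a higher number here means a weaker inhibitor, a lower number a stronger inhibitor), compound 1 gives 12 nM. Compound 2 stands at the higher of the two numbers: in this assay compound 2 gives 120 nM, and the step of a 10-fold higher number from compound 1 to compound 2 (1.00 log units; beyond the scatter) is the only one measured. Compound 3 `COc1cccc(-n2cc3nc(-c4cccnc4C)n(C[C@H]4CCCN(Cc5cnco5)C4)c(=O)c3n2)c1` is not yet measured. It differs from compound 2 by 1,3-oxazol-5-yl in place of oxan-2-yl on a saturated chain carbon bound to an amine nitrogen in a ring. Going by the values given here, no measured step covers this exchange; the single step from compound 1 to compound 2 shows only that a change at this position can move the number by a modest amount, and it offers no direction for a move to the aromatic ring. Compound 3 is therefore expected to stay near compound 2, with a step of a 1.7-fold higher number from compound 2 to compound 3 (0.22 log units; within the scatter) in this assay. The estimate for compound 3 is 200 nM, within a range of 50 nM to 800 nM.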

Compound 3, half-maximal inhibitory concentration: 120 nM
For compound 3 the middle estimate is 1.7-fold (0.22 log units) above the measured one, and the stated range covers the measured number.
By their numbers in this assay, from the lowest: compound 1; then compounds 2 and 3 (each within the scatter of the next).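

In this assay the exchange of oxan-2-yl for 1,3-oxazol-5-yl at this position gives no change at the digits printed from compound 2 to compound 3 (within the scatter) and so the six-membered non-aromatic ring and the five-membered aromatic ring cannot be told apart here. Cyclopentyl now stands apart from both groups, since the exchange for 1,3-oxazol-5-yl gives a 10-fold higher number from compound 1 to compound 3 (1.00 log units; beyond the scatter) and this step has the same printed size as a 10-fold higher number from compound 1 to compound 2 (1.00 log units; beyond the scatter) for the exchange to oxan-2-yl. Among these three compounds, the two groups with a ring hetero atom therefore sit together, and nothing available offers an explanation for this grouping.

Three compounds cannot show whether the ring hetero atom itself separates these groups from cyclopentyl, or whether it is some other difference between the rings. A phenyl or a cyclohexyl group on the same saturated chain carbon would test this, while a ring carrying an amine or a carboxylic acid would show how far the number at this position can move in either direction.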